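The source may hold more compounds than are shown below. What is called first, only, known or untested is meant among the compounds shown, and "the series" means these compounds.

Working notes on the series. Compound 1 `COc1ccc(C(=O)c2sc(Nc3ccc(C)cc3)c(C(=O)O)c2C)cc1` has no single number in a functional assay, with a stated time of 150 min, tested at 35 ug/mL (a lower number here means a weaker effect, a higher number a stronger effect of the compound at the concentration tested), and is recorded there only as "not active" (no number reported). Compound 2 `COc1ccc(Nc2sc(C(=O)c3ccc(OC)cc3)c(C)c2C(=O)O)cc1` gives 51% in this assay, and compound 3 `COc1ccc(C(=O)c2sc(Nc3ccc(F)cc3)c(C(=O)O)c2C)cc1` gives 12.8%. For the measured compounds named here, the one measured step, a number 38.2 percentage points lower from compound 2 to compound 3 (beyond the scatter), concerns fluoro in place of methoxy on an aromatic carbon and sits on a different ring from the change now followed; it therefore bears on the step from compound 1 to compound 4 only as a sign that the read-out of this assay can shift sharply with a single substituent exchange. Compound 4 `Cc1ccc(Nc2sc(C(=O)c3ccc(C)cc3)c(C)c2C(=O)O)cc1` differs from compound 1 by methyl in place of methoxy on an aromatic carbon, that is methoxy leaving and methyl entering on an aromatic carbon of a six-membered aromatic ring of carbon only, para to a large group. Going by the values given here, no measured step shows this exchange at this place, so the size and direction of the step cannot be taken from the data; the starting point, compound 1, is without activity. Compound 4 is therefore expected to stay low, with an estimate of 10% in this assay and a range from 0% to 35%.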

Compound 4, a percentage reported as activity, at one concentration (the size of the read-out at that concentration, not a potency): "not active" (no number reported)
Nothing numeric was reported for compound 4; the estimate stays without a comparison.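

In this assay compound 1 gives "not active" (no number reported) and compound 4 gives "not active" (no number reported) as well, so no step can be read between them. The compounds shown leave open whether 4-methoxyphenyl to 4-methylphenyl changes the read-out at all. No supporting data bear on this result.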